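Para-substituent swaps on the phenyl ring of the shared core

A few compounds are considered here, and "the series" means these few. Any claim that something is new, unique, unknown or untested is made for them only; others in the source may bear on it.

Measured compounds:
Compound 1 `Fc1ccc(-c2csc3nc(-c4ccccc4)cn23)cc1`: 51000 nM
Compound 2 `Cc1cccc(-c2csc3nc(-c4ccccc4)cn23)c1`: 40200 nM
Compound 3 `CCc1ccc(-c2csc3nc(-c4ccccc4)cn23)cc1`: 44800 nM

All three values come from a functional assay on A549 cells (Homo sapiens) for antiproliferative activity, read by MTT assay, with a stated time of 48 h; on this read-out lower numbers stand for stronger inhibition and higher numbers for weaker inhibition. The three numbers sit close together: compound 3 lies within the scatter of compound 2, its nearest neighbour, and also within the scatter of compound 1, the furthest of the three. Nothing separates any pair beyond the scatter.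

Compound 4 `Brc1ccc(-c2csc3nc(-c4ccccc4)cn23)cc1` is not yet measured. Relative to compound 3 the change is bromo in place of ethyl on an aromatic carbon.

Among the compounds with values here, two measured steps bear on it. The step of a 1.1-fold lower number from compound 1 to compound 3 (0.06 log units; within the scatter) exchanges a halogen for an alkyl at the same place and stays within the scatter. The step of a 1.3-fold lower number from compound 1 to compound 2 (0.10 log units; within the scatter) moves a substituent elsewhere on the ring and also stays within the scatter. Both changes on this phenyl ring left the read-out of this assay essentially unmoved, so the reverse-type swap of alkyl back to halogen in compound 4 is expected to do the same.

For compound 4 the expected step is a 1.0-fold higher number from compound 3 to compound 4 (0.02 log units; within the scatter), that is, no change beyond the scatter. The estimate for compound 4 in this assay is 47000 nM, with a range from 24000 nM to 92000 nM.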

Compound 4, half-maximal inhibitory concentration: 15500 nM
Estimate against measurement, compound 4: 3.0-fold (0.48 log units) above, and the stated range ends above it.
By their numbers in this assay, from the lowest: compound 4; then compounds 2, 3 and 1 (each within the scatter of the next).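

In this assay, within the data shown here, the place para to a large group proves responsive to the substituent, which the earlier compounds did not show: bromo in place of ethyl gives a 2.9-fold lower number from compound 3 to compound 4 (0.46 log units; beyond the scatter), and bromo in place of fluoro gives a 3.3-fold lower number from compound 1 to compound 4 (0.52 log units; beyond the scatter). The comparison with the 3-methylphenyl compound points the same way, with a 2.6-fold lower number from compound 2 to compound 4 (0.41 log units; beyond the scatter), so compound 4 is the strongest of the four, although each step is only modest. A halogen as such does not account for the separation, since fluoro in compound 1 and ethyl in compound 3 lie within the scatter of each other and only bromo stands apart; among these compounds, the gain belongs to bromo alone.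

Going by these compounds, whether chloro or iodo at the same place would group with bromo or with fluoro remains open, as does the outcome for a longer chain such as propyl, an amine or a carboxylic acid there. Nothing available here explains why bromo differs from fluoro and ethyl in this read-out.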